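The source may report more compounds than this note shows. Statements on the series, on what has been measured and on what is new or still open speak of the compounds shown alone.

Measured so far:

Compound 1, `CC(C)NC(=O)[C@H]1CN(C)C[C@@H]1c1ccc(/C=C/C(=O)Nc2ccccc2N)cc1`: 8 mL/min/kg
Compound 2, `CCN1C[C@H](C(=O)Nc2ccc(Cl)cc2)[C@@H](c2ccc(/C=C/C(=O)Nc3ccccc3N)cc2)C1`: 12 mL/min/kg

Both compounds were tested in an in vitro ADME assay on microsomes from liver (Homo sapiens) for pharmacokinetics, read by LC-MS, with a stated time of 10 min, tested at 1 uM; a lower number here means slower removal, a higher number faster removal of the compound. Compound 2 gives 12 mL/min/kg, the higher of the two numbers, while compound 1 gives 8 mL/min/kg; the gap between them lies within the scatter, so the two cannot be told apart on these numbers.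

Compound 3, `Nc1ccccc1NC(=O)/C=C/c1ccc([C@H]2CN(C3CCOCC3)C[C@@H]2C(=O)Nc2ccc(Cl)cc2)cc1`, has not yet been measured. It differs from compound 2 in one place: oxan-4-yl in place of ethyl on an amine nitrogen in a ring. No change of this kind has been measured here, so nothing in the data says which way the number should move. Within the data shown here, with only one starting value to go on, the step from compound 2 to compound 3 is expected to stay within the scatter, a 1.1-fold higher number from compound 2 to compound 3 (0.03 log units; within the scatter). Compound 3 is therefore estimated at 13 mL/min/kg, with a range from 6 mL/min/kg to 28 mL/min/kg.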

Compound 3, clearance: 12 mL/min/kg
Compound 3: middle estimate off by 1.1-fold (0.03 log units), on the high side, within the range that was stated.
By their numbers in this assay, from the lowest: compounds 1, 2 and 3 (each within the scatter of the next).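

In this assay, oxan-4-yl in place of ethyl on the amine nitrogen in the ring gives no change at the digits printed from compound 2 to compound 3 (within the scatter) for this pair. Among these compounds, this is the first reading of a change at this position, and it shows that a group of 6 heavy atoms, with one six-membered non-aromatic ring and 1 hydrogen-bond acceptor, can replace one of 2 heavy atoms without the number moving beyond the scatter. Nothing measured here gives a reason for this result.

One pair cannot show how other groups on this nitrogen would behave, such as piperidin-4-yl, which has a ring nitrogen where oxan-4-yl has its oxygen, or a chain ending in a carboxylic acid. As far as these compounds go, it also remains open whether the same change would read alike with an isopropylcarbamoyl group in place of the (4-chlorophenyl)carbamoyl group.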